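From acetylpyrrolidine to acetamide: expected rat clearance

The source may report more compounds than this note shows. Statements on the series, on what has been measured and on what is new or still open speak of the compounds shown alone.

Compound 3 `CC(=O)N1CCC(c2ccc(Nc3nc(N)n(-c4ccccn4)n3)cc2)C1` gives the lowest number of the three in an in vivo ADME assay on the whole organism for pharmacokinetics, with Rattus norvegicus as the target (a higher number here means faster removal of the compound, a lower number slower removal), at 25.1 mL/min/kg. Compound 1 `CN1CCN(c2ccc(Nc3nc(N)n(-c4ccccn4)n3)cc2)CC1` gives 84.4 mL/min/kg in this assay, and compound 2 `CN1CCC(c2cccc(Nc3nc(N)n(-c4ccccn4)n3)c2)CC1` gives 174 mL/min/kg. Among the compounds with values here, the one step that differs in a single place, a 3.4-fold lower number from compound 1 to compound 3 (0.53 log units; beyond the scatter), shows that swapping the group on this ring carbon moves the number by a modest amount. Compound 4 `CC(=O)Nc1ccc(Nc2nc(N)n(-c3ccccn3)n2)cc1` carries acetamido in place of 1-acetylpyrrolidin-3-yl on an aromatic carbon. Within the data shown here, no measured pair covers this exact swap, so its size is uncertain; the earlier step points to a modest shift at most, and both compound 3 and compound 4 keep an acetyl group. For compound 4 the expected step is a 1.4-fold higher number from compound 3 to compound 4 (0.14 log units; within the scatter), and the estimate is 35 mL/min/kg, within 15 mL/min/kg to 80 mL/min/kg.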

Compound 4, clearance: 42.1 mL/min/kg
For compound 4 the middle estimate is 1.2-fold (0.08 log units) below the measured one, within the range that was stated.
By their numbers in this assay, from the lowest: compounds 3, 4 and 1 (each within the scatter of the next, the first and the last beyond it); then compound 2.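

On this aromatic carbon, acetamido gives a 1.7-fold higher number from compound 3 to compound 4 (0.22 log units; within the scatter), so the ring of 1-acetylpyrrolidin-3-yl can go without a step beyond the scatter. Acetamido also gives a 2.0-fold lower number from compound 1 to compound 4 (0.30 log units; within the scatter), which leaves compound 4 within the scatter of both compound 1 and compound 3, even though those two lie beyond the scatter of each other. Still open, as far as these compounds go, is whether a carboxylic acid or a primary amine in this place would stay within the scatter of compound 4. Nothing measured here explains these steps.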